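The source may report more compounds than this note shows. Statements on the series, on what has been measured and on what is new or still open speak of the compounds shown alone.

Compound 2 `CCCSc1nc(=O)ccn1[C@@H]1O[C@H](COP(=O)(O)OP(=O)(O)O)[C@@H](O)[C@H]1O` has the highest of the two numbers in an in vitro functional assay on 1321-N1 cells for agonist activity at P2Y purinoceptor 4 (Homo sapiens), read by scintillation proximity assay and inositol phosphate accumulation (on this read-out higher numbers stand for an effect only at larger amounts of compound and lower numbers for an effect already at smaller amounts), where compound 2 gives 4900 nM; compound 1 `CSc1nc(=O)ccn1[C@@H]1O[C@H](COP(=O)(O)OP(=O)(O)O)[C@@H](O)[C@H]1O` gives 1520 nM. Compound 3 `COc1nc(=O)ccn1[C@@H]1O[C@H](COP(=O)(O)OP(=O)(O)O)[C@@H](O)[C@H]1O` differs from compound 2 by methoxy in place of propylsulfanyl on an aromatic carbon. Among the compounds with values here, the one measured step that bears on this, a 3.2-fold higher number from compound 1 to compound 2 (0.51 log units; beyond the scatter), was a modest rise when the chain on the sulfur grew. Shortening the group again should therefore bring the number back down, though the swap of sulfur for oxygen has no measured counterpart here, so the expected step is a 2.7-fold lower number from compound 2 to compound 3 (0.43 log units; beyond the scatter), a modest fall. Compound 3 is expected at 1800 nM, within 700 nM to 5000 nM.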

Compound 3, half-maximal effective concentration: 4490 nM
The estimate for compound 3 lay 2.5-fold (0.40 log units) below the measured number; the measured number falls inside the stated range.
By their numbers in this assay, from the lowest: compound 1; then compounds 3 and 2 (each within the scatter of the next).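

In this assay, methoxy in place of propylsulfanyl on this aromatic carbon gave a 1.1-fold lower number from compound 2 to compound 3 (0.04 log units; within the scatter) and so made no difference that can be read, although the group entering has fewer heavy atoms. Methoxy in place of methylsulfanyl gave a 3.0-fold higher number from compound 1 to compound 3 (0.47 log units; beyond the scatter), so among these three compounds only compound 1 stands apart, and the size of the group alone does not order them. Nothing available explains this pattern. From the compounds shown here alone, whether an amine or a longer chain on oxygen at this carbon would change the number remains open.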